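A few compounds are considered here, and "the series" means these few. Any claim that something is new, unique, unknown or untested is made for them only; others in the source may bear on it.

Measured in a functional assay on RS4-11 cells (Homo sapiens) for inhibition, read by CCK-8 assay, with a stated time of 48 h, tested at 20 uM; a higher number here means more inhibition of growth at the concentration tested, a lower number less inhibition of growth:
Compound 1 `N#C/C(=C\c1ccccc1OS(=O)(=O)c1ccc(F)cc1)C(=O)Nc1nnc(Cc2cccc3ccccc23)s1`: 68%
Compound 2 `N#C/C(=C\c1ccccc1OS(=O)(=O)c1ccc(F)cc1)C(=O)Nc1nnc(Cc2cccc(F)c2)s1`: 72%
Compound 3 `Cc1ccc(Cc2nnc(NC(=O)/C(C#N)=C/c3ccccc3OS(=O)(=O)c3ccccc3[N+](=O)[O-])s2)cc1`: "not active" (no number reported)

Compound 3 has no number to stand on: in this assay compound 3 is reported only as "not active" (no number reported). Compound 4 `Cc1ccc(Cc2nnc(NC(=O)/C(C#N)=C/c3ccccc3OS(=O)(=O)c3ccc(F)cc3)s2)cc1` differs from it in one place: 4-fluorophenyl in place of 2-nitrophenyl on a sulfonyl sulfur. Put simply, this is 4-fluorophenyl in place of 2-nitrophenyl on a sulfonyl sulfur.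

For the measured compounds named here, no measured step covers this exchange. The only one available, a number 4 percentage points higher from compound 1 to compound 2 (within the scatter), lies at a different place, a saturated chain carbon bound to an aromatic carbon. It hints that, in this pair, exchanging the group at that place left the reading within the scatter. The closer guide is the 4-fluorophenyl group itself: with it on the sulfonyl sulfur, compound 1 gives 68% and compound 2 gives 72%. Compound 4 keeps the group of compound 3 at the chain carbon, and that group has not been measured alongside 4-fluorophenyl. An upward step is therefore expected, large but impossible to size exactly, since its starting point has no number. For compound 4 the expected value is 62%, with an estimated range of 35% to 80%.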

Compound 4, percent growth inhibition at one concentration: 73%
Compound 4: the middle estimate sits 11 percentage points below what was measured; the measured number falls inside the stated range.
By their numbers in this assay, from the lowest: compounds 1, 2 and 4 (each within the scatter of the next).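

In this assay compound 3 stands as "not active" (no number reported) while compound 4 gives 73% under the same conditions. On the sulfonyl sulfur, then, 4-fluorophenyl in place of 2-nitrophenyl separates a compound with a measured number from one without, although the size of that step cannot be read. With 4-fluorophenyl held on the sulfonyl sulfur, 4-methylphenyl on the saturated chain carbon gives a number 1 percentage points higher from compound 2 to compound 4 (within the scatter) and a number 5 percentage points higher from compound 1 to compound 4 (within the scatter) so compounds 1, 2 and 4 all lie within the scatter of one another, and the 4-methylphenyl, 3-fluorophenyl and naphthalen-1-yl groups cannot be told apart at that place.

As far as these compounds go, what 4-nitrophenyl or 2-fluorophenyl on the sulfonyl sulfur would give remains open, so the nitro group and its place on the ring cannot yet be separated as the feature that goes with the missing number. Also open, from the compounds shown here alone, is whether the chain carbon would tolerate a group without an aromatic ring, such as an amine or a longer alkyl chain. No measurement here explains why these compounds read as they do.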